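The compounds below may be only part of what the source reports. "The series", "measured", "known", "first", "only" and "open" are said of these compounds alone.

Working notes on the series. Solubility across the set was measured in a physicochemical assay for solubility, with a stated time of 18 h, at pH 7.4; a lower number here means a less soluble compound, a higher number a more soluble compound. Compound 1, `CC(C)(C)c1ccc(Oc2ccc3c(NCCCNCc4ccco4)ccnc3c2)cc1`, gives 14500 nM in this assay. Compound 2, `COc1ccc(F)cc1CNCCCNc1ccnc2cc(Oc3ccc(F)cc3)ccc12`, gives 14500 nM, the same number at the digits shown as compound 1; the two stand together at the top of the three values, within the scatter of each other. Compound 3, `COc1ccc(F)cc1CNCCCNc1ccnc2cc(Cc3ccc(F)cc3Cl)ccc12`, gives 4200 nM, the lowest number of the set. Among the compounds with values here, the only single-point step among the measured compounds is a 3.5-fold lower number from compound 2 to compound 3 (0.54 log units; beyond the scatter).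

Compound 4, `c1ccc(Oc2ccc3c(NCCCNCc4ccco4)ccnc3c2)cc1`, is the next member of the series. It differs from compound 1 by hydrogen in place of tert-butyl on an aromatic carbon. Within the data shown here, no measured step involves the same change: the one measured step, from compound 2 to compound 3, replaces one aryl-linked group with another, and nothing in the set removes a tert-butyl group. Among the measured compounds shown here, the step to compound 4 therefore has no direct precedent here, and only the size of the change itself, four heavy atoms leaving with nothing entering, offers a guide. A modest upward step is expected, plausibly near the edge of the scatter rather than far beyond it; the step of a 2.1-fold higher number from compound 1 to compound 4 (0.32 log units; beyond the scatter) is the estimate adopted. Compound 4 is accordingly expected to give about 30000 nM in this assay, with a range of 10000 nM to 90000 nM.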

Compound 4, solubility: 14500 nM
Beside the measured number, compound 4's estimate is 2.1-fold (0.32 log units) above it; the range from low to high includes it.
By their numbers in this assay, from the lowest: compound 3; then compounds 1, 2 and 4 (each within the scatter of the next).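

In this assay, the change from 4-(tert-butyl)phenyl to phenyl gives no change at the digits printed from compound 1 to compound 4 (within the scatter), so at this aromatic carbon the loss of 4 heavy atoms, all carbon, with only hydrogen entering leaves the read-out unmoved within the scatter. The earlier step, a 3.5-fold lower number from compound 2 to compound 3 (0.54 log units; beyond the scatter), replaced the whole group on the aromatic carbon of the core, whereas this step keeps the oxygen-linked phenyl ring and alters only what it carries, giving the first read on that outer position. No measurement in the set addresses why the number holds across this change.

Left open is whether this position is as undemanding for groups of a different kind, such as a primary amine or a carboxylic acid in place of the tert-butyl, since hydrogen and tert-butyl are the only two substituents shown there. Within the data shown here, also open is whether the same replacement reads the same way when the side chain of compound 2 stands in place of the one shared by compound 1 and compound 4.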